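This account rests on a few compounds, and the source may have more. Where it says the series, first, only, none or still open, it means among the compounds named here.

Working notes on the series

- compound 1 `COc1ccc(-c2cc(N)c(C(=O)c3cc(OC)c(OC)c(OC)c3)s2)cc1OC` gives 20 nM in a functional assay on MOLT-4 cells (Homo sapiens) for antiproliferative activity (on this read-out lower numbers stand for stronger inhibition and higher numbers for weaker inhibition), as its read-out
- compound 2 `COc1cc(C(=O)c2sc(-c3ccccc3Cl)cc2N)cc(OC)c1OC` gives 17 nM in this assay as well

For the measured compounds named here, compound 1 lies within the scatter of compound 2, the only other measured compound, so the two cannot be ranked. Compound 3 `COc1cc(C(=O)c2sc(-c3cc(OC)c(OC)c(OC)c3)cc2N)cc(OC)c1OC` differs from compound 1 by one change, methoxy in place of hydrogen on an aromatic carbon with methoxy in place of hydrogen on an aromatic carbon. Going by the values given here, no measured step isolates this change. Among the compounds with values here, the only step available is a 1.2-fold lower number from compound 1 to compound 2 (0.07 log units; within the scatter) and it lies within the scatter, although it swaps 3,4-dimethoxyphenyl for 2-chlorophenyl. This is thin evidence, since it is a single step of a different kind. Even so, for one added methoxy, no shift beyond the scatter is expected in this assay and neither direction is favoured. The expected step is a 1.1-fold higher number from compound 1 to compound 3 (0.04 log units; within the scatter) and this estimate stays within the scatter. Within the data shown here, the range is kept wide because only two measured values support it. Compound 3 is estimated at 22 nM with an expected span from 8 nM to 60 nM as its range.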

Compound 3, half-maximal inhibitory concentration: 1200 nM
Compound 3: the middle estimate sits 55-fold (1.74 log units) below what was measured, and the stated range ends below it.
By their numbers in this assay, from the lowest: compounds 2 and 1 (each within the scatter of the next); then compound 3.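

In this assay, a 60-fold higher number from compound 1 to compound 3 (1.78 log units; beyond the scatter) shows that this aromatic carbon, ortho to a methoxy group and meta to a large group, is far from indifferent to substitution: one methoxy in place of hydrogen is enough to take the number beyond the scatter. The earlier comparison gave no sign of this, since a 1.2-fold lower number from compound 1 to compound 2 (0.07 log units; within the scatter) replaced 3,4-dimethoxyphenyl with 2-chlorophenyl and stayed within the scatter, so a large change to this ring can leave the read-out in place while a small one at this carbon does not. Nothing at hand gives a reason for the size of this step.

The compounds shown leave open whether the weaker inhibition follows from any group at this carbon or from methoxy in particular, a question that fluorine, a hydroxyl or an ethoxy at the same place would address. They also leave open whether the step depends on the neighbouring methoxy groups of compound 1, or would appear with the same added methoxy on a ring carrying only one of them.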